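A few compounds are considered here, and "the series" means these few. Any claim that something is new, unique, unknown or untested is made for them only; others in the source may bear on it.

For the measured compounds named here, compound 2 `CCCc1nc(C)c2c(C)nnc(S)n12` is one of only two compounds that have been tested in a functional assay for inhibition, with Homo sapiens as the target; on this read-out lower numbers stand for stronger inhibition and higher numbers for weaker inhibition. In this assay, going by the values given here, compound 2 gives 45000 nM, the single real number in the set. Compound 1 `CCCc1ncc2c(C)nnc(O)n12` reaches only a limit of this assay, namely > 48000 nM, so no number is known for it. Among the compounds with values here, compound 2 therefore stands at the one measured value, while the other result sits at the limit (the limit of > 48000 nM in this assay, at which 1 of the 2 values shown sits). Compound 3 `CCCc1ncc2c(C)nnc(S)n12` has not yet been measured. It differs from compound 2 by a single change, (hydrogen in place of methyl on an aromatic carbon), that is, hydrogen in place of methyl on an aromatic carbon. Within the data shown here, no step between two measured compounds exists to show how such a change acts here, so the expected step of a 1.3-fold higher number from compound 2 to compound 3 (0.12 log units; within the scatter) is small and may not exceed the usual scatter. Compound 3 is accordingly expected to give 60000 nM in this assay, somewhere between 20000 nM and 150000 nM, with a fair chance that only a limit is reported.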

Compound 3, half-maximal inhibitory concentration: > 48000 nM
Compound 3 gave a limit, no number; the forecaster's own chance of this, stated with the estimate: 55%; the middle value is on the limit's open side.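

Taking the methyl off this aromatic carbon gives the first step at this position in this assay: an at least 1.0-fold higher number from compound 2 to compound 3 (0.02 log units; that floor lies within the scatter). As far as these compounds go, that floor does not separate the two compounds, so this change has no demonstrated effect, and its real size stays unknown. The change from hydroxy to sulfanyl on the other aromatic carbon cannot be read, because compound 1 and compound 3 both stop at the same limit: the limit of > 48000 nM in this assay, at which 2 of the 3 values shown sit.

From the compounds shown here alone, it remains open whether a larger replacement at the methyl position, such as an amine or an ethyl group, would produce a clear step in this assay. Going by these compounds, it is equally open whether a longer chain in place of the propyl group, or a carboxylic acid in place of the sulfanyl group, would bring the read-out clear of the limit.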